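The source may hold more compounds than are shown below. What is called first, only, known or untested is meant among the compounds shown, and "the series" means these compounds.

Compounds measured so far:
Compound 1 `CCN(Cc1ccc(OCCn2c(=O)ccn(C)c2=O)c(C)c1)C(CC(=O)O)c1ccc(Cl)cc1`: 2.1 nm/s
Compound 2 `Cc1cc(CN(CC2CC2)C(CC(=O)O)c2ccc(Cl)cc2)ccc1OCCn1c(=O)ccn(C)c1=O`: 3.7 nm/s

Only these two compounds have numbers in an ADME assay on Caco-2 cells (Homo sapiens) for permeability, read by LC-MS, with a stated time of 2 h; a lower number here means that the compound crosses the layer more slowly, a higher number that the compound crosses the layer faster. Compound 2, at 3.7 nm/s, stands within the usual scatter of compound 1, at 2.1 nm/s, so neither can be ranked firmly against the other.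

The next compound is compound 3 `Cc1cc(CN(C2CCC2)C(CC(=O)O)c2ccc(Cl)cc2)ccc1OCCn1c(=O)ccn(C)c1=O`, which has cyclobutyl in place of cyclopropylmethyl on an amine nitrogen. The two compounds hold the same atoms, joined differently.

Within the data shown here, one measured step bears on this change. It is a 1.8-fold higher number from compound 1 to compound 2 (0.25 log units; within the scatter), and it too alters the carbon group on that amine nitrogen. Among the measured compounds shown here, that step stays within the scatter, but it is a single comparison, and no measured compound carries cyclobutyl. The data therefore point to no direction for compound 3 in this assay, and no shift beyond the scatter is expected. The expected step is a 1.1-fold lower number from compound 2 to compound 3 (0.02 log units; within the scatter). For compound 3 the estimated value is 3.5 nm/s, with an expected range of 1.6 nm/s to 7.5 nm/s.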

Compound 3, apparent permeability: 5 nm/s
Compound 3: the middle estimate sits 1.4-fold (0.15 log units) below what was measured; low and high end bracket the measured number.
By their numbers in this assay, from the lowest: compounds 1, 2 and 3 (each within the scatter of the next, the first and the last beyond it).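

Cyclobutyl in place of cyclopropylmethyl on the amine nitrogen gives a 1.4-fold higher number from compound 2 to compound 3 (0.13 log units; within the scatter) in this assay, so two groups of equal heavy-atom count but different ring size cannot be told apart at this position. Against ethyl, the picture is firmer than before: cyclobutyl in place of ethyl gives a 2.4-fold higher number from compound 1 to compound 3 (0.38 log units; beyond the scatter), a modest step and the first at this position to lie beyond the scatter, while the step to the cyclopropylmethyl compound, a 1.8-fold higher number from compound 1 to compound 2 (0.25 log units; within the scatter), stays within it. No measurement given here accounts for these numbers.

Going by these compounds, the three compounds share one core and compare only ethyl, cyclopropylmethyl and cyclobutyl on this nitrogen, so it remains open whether the modest step from ethyl to cyclobutyl would hold on another core. On these data alone, it also remains open how this assay would respond to a cyclopentyl or an isopropyl group on the amine nitrogen, or to an ester in place of the carboxylic acid of the shared core.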